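From tert-butyl to carboxymethyl on an amine nitrogen

This account rests on a few compounds, and the source may have more. Where it says the series, first, only, none or still open, it means among the compounds named here.

Measured so far in a functional assay on SK-BR-3 cells (Homo sapiens) for antiproliferative activity; on this read-out higher numbers stand for weaker inhibition and lower numbers for stronger inhibition:
compound 1 `CC(C)=CCc1cc(C(=O)Nc2cc3ccc(OCCCN4CCCC4)c(C)c3oc2=O)ccc1O` gives 720 nM
compound 2 `CC(C)=CCc1cc(C(=O)Nc2cc3ccc(OCCCNC(C)(C)C)c(C)c3oc2=O)ccc1O` gives 660 nM

These two compounds share a core and differ only in the amine group on the chain. The numbers show a 1.1-fold lower number from compound 1 to compound 2 (0.04 log units; within the scatter), so compound 2 stands level with compound 1 on this read-out.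

The next compound, compound 3 `CC(C)=CCc1cc(C(=O)Nc2cc3ccc(OCCCNCC(=O)O)c(C)c3oc2=O)ccc1O`, keeps the rest of compound 2 and places carboxymethyl in place of tert-butyl on an amine nitrogen.

Within the data shown here, only one measured step bears on this change, and it is a limited guide. That step, a 1.1-fold lower number from compound 1 to compound 2 (0.04 log units; within the scatter), swapped pyrrolidin-1-yl for (tert-butyl)amino and brought in no carboxymethyl group. Among the measured compounds shown here, no measured compound carries that group, so a flat result cannot simply be carried over. The new group also differs more from tert-butyl in what is counted than the earlier swap did, so a cautious lean towards weaker inhibition seems reasonable. The expected change is a 2.3-fold higher number from compound 2 to compound 3 (0.36 log units; beyond the scatter) in this assay, with real uncertainty in its size. For compound 3 the estimated value is 1500 nM, with an expected range from 500 nM to 6000 nM.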

Compound 3, half-maximal inhibitory concentration: 7570 nM
For compound 3 the middle estimate is 5.0-fold (0.70 log units) below the measured one; the whole stated range lies below it.
By their numbers in this assay, from the lowest: compounds 2 and 1 (each within the scatter of the next); then compound 3.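

Among these compounds, the two earlier compounds gave the impression that the group on this amine nitrogen could vary freely, but they covered only two carbon-based groups; in this assay the steps of an 11-fold higher number from compound 2 to compound 3 (1.06 log units; beyond the scatter) and an 11-fold higher number from compound 1 to compound 3 (1.02 log units; beyond the scatter) show that this position does respond strongly to what is placed there. The change is also not one of heavy-atom count, since tert-butyl and carboxymethyl each have 4 heavy atoms; what differs is that carboxymethyl has 2 oxygen atoms in place of 2 carbon atoms, a double bond, 1 hydrogen-bond donor and 1 hydrogen-bond acceptor. No measurement here links any of these differences to the loss of activity, so the reason for it remains unknown.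

Going by these compounds, with a single compound of this kind, it remains open which part of the carboxymethyl group matters. A methyl ester of the carboxylic acid, a primary amide in its place, a 2-hydroxyethyl group on the same nitrogen or a longer chain carrying the carboxylic acid would each help to separate these features.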